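Cinnamoyl sulfonamides: halogen swap on the sulfonyl ring

The source may hold more compounds than are shown below. What is called first, only, known or untested is meant among the compounds shown, and "the series" means these compounds.

Measured so far:
compound 1 `O=C(/C=C/c1ccc(Cl)cc1)NS(=O)(=O)c1ccc(Br)cc1` — 2.8 ug/mL
compound 2 `COc1ccc(/C=C/C(=O)NS(=O)(=O)c2ccccc2)cc1` — 13.2 ug/mL
compound 3 `COc1ccc(/C=C/C(=O)NS(=O)(=O)c2ccc(F)cc2)cc1` — 5.1 ug/mL

In a functional assay on B16-F10 cells (Mus musculus) for antiproliferative activity, read by ELISA and MTT assay, with a stated time of 48 h (on this read-out higher numbers stand for weaker inhibition and lower numbers for stronger inhibition), compound 3 gives 5.1 ug/mL, the second highest of the three numbers. Its nearest neighbour is compound 1, which in this assay gives 2.8 ug/mL, a difference within the scatter; the furthest is compound 2, which gives 13.2 ug/mL, a gap beyond the scatter.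

The next compound, compound 4 `COc1ccc(/C=C/C(=O)NS(=O)(=O)c2ccc(Br)cc2)cc1`, differs from compound 3 by bromo in place of fluoro on an aromatic carbon.

Among the compounds with values here, only one measured step touches the same position. The step of a 2.6-fold lower number from compound 2 to compound 3 (0.41 log units; beyond the scatter) placed a halogen where hydrogen had been and lowered the number by a modest, beyond-scatter amount. Within the data shown here, no measured pair shows bromo in place of fluoro on that ring; compound 1 carries bromo there but differs in a second place too, so its number can only be noted alongside. On this basis a small further lowering, or none beyond the scatter, is expected, giving a 1.5-fold lower number from compound 3 to compound 4 (0.16 log units; within the scatter) for compound 4. Compound 4 is therefore estimated to give 3.5 ug/mL in this assay, with the range 1.8 ug/mL to 7 ug/mL.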

Compound 4, half-maximal inhibitory concentration: 5.8 ug/mL
The estimate for compound 4 lay 1.7-fold (0.22 log units) below the measured number, within the range that was stated.
By their numbers in this assay, from the lowest: compounds 1, 3 and 4 (each within the scatter of the next, the first and the last beyond it); then compound 2.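

In this assay the change from 4-fluorophenyl to 4-bromophenyl gives a 1.1-fold higher number from compound 3 to compound 4 (0.06 log units; within the scatter), so these two halogens cannot be told apart at this position. Bromo in place of hydrogen gives a 2.3-fold lower number from compound 2 to compound 4 (0.36 log units; beyond the scatter), alongside a 2.6-fold lower number from compound 2 to compound 3 (0.41 log units; beyond the scatter), so in these three compounds the gain over hydrogen is seen with either halogen, and its size does not separate them. Compound 4 also gives the first one-place comparison away from this position, with methoxy in place of chloro and bromo held constant: a 2.1-fold higher number from compound 1 to compound 4 (0.32 log units; beyond the scatter), which shows that the number still responds to a change at that other aromatic carbon while the swap of fluoro for bromo leaves it unresolved.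

On these data alone, it remains open whether chloro, an amine or a carboxylic acid at this position would follow the two halogens, and whether the methoxy-to-chloro difference would carry over to a compound with fluoro or hydrogen in place of bromo. Nothing available explains any of these steps.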